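Moving one methyl: from compound 3 to compound 4

The source may report more compounds than this note shows. Statements on the series, on what has been measured and on what is new or still open speak of the compounds shown alone.

Measured in a functional assay on MDA-MB-468 cells (Homo sapiens) for antiproliferative activity, read by MTT assay, with a stated time of 72 h; on this read-out lower numbers stand for stronger inhibition and higher numbers for weaker inhibition:
Compound 1 `COc1cc(-c2nccn2C)cc(OC)c1OC`: > 100000 nM (a limit)
Compound 2 `CCn1ccnc1-c1cc(OC)c(OC)c(OC)c1`: > 100000 nM (a limit)
Compound 3 `COc1cc(-c2nccn2-c2ccc(C)cc2)cc(OC)c1OC`: 400 nM

Among the measured compounds shown here, compound 3, at 400 nM, holds the only true number in this set. The two other values are limits. Compound 4 `COc1cc(-c2nccn2-c2cccc(C)c2)cc(OC)c1OC` carries 3-methylphenyl in place of 4-methylphenyl on an aromatic nitrogen. For the measured compounds named here, two measured steps bear on this nitrogen, an at least 250-fold lower number from compound 1 to compound 3 (2.39 log units; beyond the scatter) and an at least 250-fold lower number from compound 2 to compound 3 (2.39 log units; beyond the scatter), and both are large. They show that the group placed there can matter greatly in this assay. Neither of them shifts the methyl within the phenyl group, however, so they give no direct size for the present change. A moderate rise in the number is expected, a 2.5-fold higher number from compound 3 to compound 4 (0.40 log units; beyond the scatter), although a result within the scatter would not surprise. For compound 4 the estimated value is 1000 nM. The expected range runs from 200 nM to 5000 nM.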

Compound 4, half-maximal inhibitory concentration: 22600 nM
For compound 4 the middle estimate is 23-fold (1.35 log units) below the measured one, and the stated range ends below it.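

In this assay, among the compounds shown here, the earlier compounds showed that the group on this aromatic nitrogen can matter greatly, and compound 4 shows that the same atoms, joined differently, can matter greatly too, with a 57-fold higher number from compound 3 to compound 4 (1.75 log units; beyond the scatter). The 3-methylphenyl group still keeps an edge over the two small chains, with an at least 4.4-fold lower number from compound 2 to compound 4 (0.64 log units; beyond the scatter) and with an at least 4.4-fold lower number from compound 1 to compound 4 (0.64 log units; beyond the scatter), so most of the gain seen with 4-methylphenyl is lost on moving one methyl. Those two steps give only a minimum size, because each starts from a limit of the assay: the limit of > 100000 nM in this assay, at which 2 of the 4 values shown sit.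

The compounds shown leave open how a plain phenyl group, or a phenyl group carrying a chlorine or a methoxy group, would stand on this nitrogen. They also give no cause for the size of the methyl shift.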